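The source may report more compounds than this note shows. Statements on the series, on what has been measured and on what is new or still open speak of the compounds shown alone.

Compound 1, `CC(C)[C@H](NC(=O)COc1cccc2ccccc12)C(=O)N[C@@H](CC(=O)O)C(=O)COc1cccc2ccccc12`: in a functional assay on Jurkat cells (Homo sapiens) (on this read-out lower numbers stand for stronger inhibition and higher numbers for weaker inhibition), compound 1 gives > 100000 nM, which is a limit of the assay and not a number.
Compound 2, `CC(=O)Nc1cccc(OCC(=O)[C@H](CC(=O)O)NC(=O)[C@@H](NC(=O)COc2cccc3ccccc23)C(C)C)c1`: in this assay compound 2 gives > 100000 nM, again a limit of the assay rather than a number.

Within the data shown here, compound 2 therefore stands at the limit, and nothing places it relative to compound 1: the one measured step, a step that the two limits leave unreadable from compound 1 to compound 2, cannot be read, since both of its ends are limits. Among the measured compounds shown here, the only evidence is the limit of > 100000 nM in this assay, at which 2 of the 2 values shown sit.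

Compound 3, `CC(C)[C@H](NC(=O)COc1cccc2ccccc12)C(=O)N[C@@H](CC(=O)O)C(=O)COc1c(F)ccc(F)c1F`, has yet to be measured. It differs from compound 2 in one place: 2,3,6-trifluorophenyl in place of 3-acetamidophenyl on an oxygen on a saturated carbon. For the measured compounds named here, no measured step involves a trifluorophenyl group, so no step bears directly on this change; the one step available is unreadable in size. With both measured compounds at the limit, the change is expected to leave compound 3 at or near that limit, and the step is estimated as a number no higher from compound 2 to compound 3 (the limit leaves the size open), which is no more than the scatter would allow. For compound 3 the expected value in this assay is 100000 nM, with a range from 20000 nM to 500000 nM.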

Compound 3, half-maximal inhibitory concentration: 1200 nM
Compound 3: the middle estimate sits 83-fold (1.92 log units) above what was measured; the whole stated range lies above it.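

In this assay the group on an oxygen on a saturated carbon proves able to decide whether a value can be read at all: 2,3,6-trifluorophenyl in place of 3-acetamidophenyl gives an at least 83-fold lower number from compound 2 to compound 3 (1.92 log units; beyond the scatter), and the same group in place of naphthalen-1-yl gives an at least 83-fold lower number from compound 1 to compound 3 (1.92 log units; beyond the scatter). The rest of the molecule is therefore compatible with a measurable value, and the two earlier compounds had not shown this, as neither gave a number. Compound 1 and compound 2 remain limits of the assay rather than numbers, so the step between them cannot be read and the two groups they carry cannot be ranked against each other, and the evidence for that is only this: the limit of > 100000 nM in this assay, at which 2 of the 3 values shown sit.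

Going by these compounds, what a plain phenyl or a 2,6-difluorophenyl group would give at this place stays open, and with it whether all three fluorine atoms of the entering group count. Also open, on these data alone, is whether the value of compound 3 depends on the second naphthalen-1-yl group it keeps, which a phenyl or a benzyl group in that group's place would test.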